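A few compounds are considered here, and "the series" means these few. Any claim that something is new, unique, unknown or untested is made for them only; others in the source may bear on it.

Going by the values given here, compound 2 `O=C(c1ccc(-c2ccc3ncc(-c4ccc5ncccc5c4)n3c2)cc1)N1CCOCC1` gives 74.7% in an assay on Sf21 cells for inhibition of MAP kinase-interacting serine/threonine-protein kinase 1 (Homo sapiens), read by luminescence and ADP-Glo, with stated times of 10 min and 40 min, tested at 500 nM (on this read-out higher numbers stand for more inhibition at the one concentration tested (going by the name of the read-out) and lower numbers for less inhibition), the lower of the two numbers measured so far. Among the compounds with values here, compound 1 `O=C(c1ccc(-c2ccc3ncc(-c4ccc5cnccc5c4)n3c2)cc1)N1CCOCC1` gives 93.7%, and the only measured step, a number 19 percentage points lower from compound 1 to compound 2 (beyond the scatter), came with the exchange of isoquinolin-6-yl for quinolin-6-yl on an aromatic carbon. Compound 3 `O=C(c1ccc(-c2ccc3ncc(-c4ccc5ncccc5c4)n3c2)cc1)N1CCNCC1` has not yet been measured. It differs from compound 2 at the other end of the molecule: piperazin-1-yl in place of morpholin-4-yl on a carbonyl carbon. No measured step touches the group on the carbonyl carbon, so nothing shown here tells how that exchange moves the read-out; the one known step concerns a different place and only shows that a single swap can shift the number beyond the scatter. With no direct guide, the expected step of a number 2.7 percentage points lower from compound 2 to compound 3 (within the scatter) is small, none beyond the scatter. Compound 3 is therefore estimated at 72%, with a range from 55% to 86%.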

Compound 3, a percentage reported as inhibition, at one concentration (the size of the read-out at that concentration, not a potency): 73.5%
Compound 3: the middle estimate sits 1.5 percentage points below what was measured; the range from low to high includes it.
By their numbers in this assay, from the lowest: compounds 3 and 2 (each within the scatter of the next); then compound 1.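

In this assay, the exchange of morpholin-4-yl for piperazin-1-yl on the carbonyl carbon gives a number 1.2 percentage points lower from compound 2 to compound 3 (within the scatter), even though the entering ring carries a hydrogen-bond donor and the leaving ring carries none. So this end of the molecule accepts this particular swap with no readable difference, whereas the earlier exchange of isoquinolin-6-yl for quinolin-6-yl, at the other end, gave a number 19 percentage points lower from compound 1 to compound 2 (beyond the scatter). Nothing measured here bears on the reason for this result.

Still open, going by these compounds, is whether a different group on the carbonyl carbon, such as an open-chain dimethylamino group or a piperazine with a methyl on its free nitrogen, would also keep the number in place. Also open, on these data alone, is whether piperazin-1-yl behaves the same way when isoquinolin-6-yl stands at the other end, as it does in compound 1.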